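The source may hold more compounds than are shown below. What is called first, only, known or untested is meant among the compounds shown, and "the series" means these compounds.

Measured compounds in a functional assay on HL-60 cells (Homo sapiens) for inhibition, read by CCK-8 assay, with a stated time of 48 h; a lower number here means a stronger inhibitor, a higher number a weaker inhibitor:

Compound 1 `O=C(NCCNS(=O)(=O)c1ccc(-c2ccccc2OCc2cccc(O)c2)s1)Nc1cc(Cl)cc(Cl)c1` gives 2800 nM.
Compound 2 `O=S(=O)(NCCNC(=S)Nc1cccc(Cl)c1)c1ccc(-c2ccccc2OCc2cccc(O)c2)s1` gives 1800 nM.
Compound 3 `Cc1cc(C)cc(NC(=O)NCCNS(=O)(=O)c2ccc(-c3ccccc3OCc3cccc(O)c3)s2)c1` gives only a limit of the assay, > 20000 nM.

Compound 3 thus stands at the limit rather than at a number, the point (the limit of > 20000 nM in this assay, at which 1 of the 3 values shown sits). The measured steps all concern the substituent on the urea or thiourea nitrogen: a 1.6-fold lower number from compound 1 to compound 2 (0.19 log units; within the scatter); an at least 7.1-fold higher number from compound 1 to compound 3 (0.85 log units; beyond the scatter); an at least 11-fold higher number from compound 2 to compound 3 (1.04 log units; beyond the scatter). The steps into compound 3 are both beyond the scatter and run toward weaker inhibition.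

Compound 4 `Cc1cc(C)cc(NC(=O)NCCNS(=O)(=O)c2ccc(-c3ccccc3Oc3ccc(N)cc3)s2)c1` keeps the 3,5-dimethylphenyl urea of compound 3 and changes the other end: 4-aminophenyl in place of 3-hydroxybenzyl on an oxygen on an aromatic ring. Cut one bond further out, the change reads (3-hydroxybenzyl)oxy to 4-aminophenoxy. None of the measured steps touches this part of the molecule, so no measured step bears on the change, and its direction in this assay cannot be read from the shown compounds. What is known is that compound 3 already sits at the limit, so the starting point is weak.

Within the data shown here, with no step to lean on, the expectation for compound 4 is that it stays near the limit, the estimated step being a step that the limit leaves unreadable from compound 3 to compound 4. Compound 4 is therefore estimated at 25000 nM, in a range from 6000 nM to 100000 nM, most probably reported again only as a limit.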

Compound 4, half-maximal inhibitory concentration: > 50000 nM
Compound 4: only a limit was reported (the forecaster's own chance of this, stated with the estimate: 70%); middle value at least 2.0-fold (0.30 log units) away from the limit.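

In this assay compound 3 gives > 20000 nM, a limit of the assay. Among these compounds, compound 4 gives > 50000 nM, also a limit, so no step from compound 3 to compound 4 can be read. The compounds shown leave open whether 4-aminophenyl in place of 3-hydroxybenzyl on an oxygen on an aromatic ring changes inhibition in either direction.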